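From a Morpholine Amide to a Trifluoromethylpiperidine Amide

The source may report more compounds than this note shows. Statements on the series, on what has been measured and on what is new or still open speak of the compounds shown alone.

Going by the values given here, compound 3 `CCN(CC)S(=O)(=O)c1ccc(S(=O)(=O)N2CCC[C@@H](C(=O)N3CCOCC3)C2)cc1` is one of three compounds measured in a functional assay on MIA PaCa-2 cells (Homo sapiens) for inhibition, read by MTT assay, with a stated time of 3 days (on this read-out higher numbers stand for weaker inhibition and lower numbers for stronger inhibition), where compound 3 gives 160 nM, the highest of the three numbers. Compound 1 `O=C([C@@H]1CCCN(S(=O)(=O)c2ccc(S(=O)(=O)C3CCC3)cc2)C1)N1CCC(F)(F)CC1` gives 12.6 nM and compound 2 `CC(C)S(=O)(=O)c1ccc(S(=O)(=O)N2CCC[C@@H](C(=O)N3CCC(F)(F)CC3)C2)cc1` gives 9.1 nM. Both sit well below compound 3, and the gap from compound 3 to each of them lies beyond the scatter. Among the compounds with values here, the only one-place step among the measured compounds is a 1.4-fold lower number from compound 1 to compound 2 (0.14 log units; within the scatter); it concerns the group on a sulfonyl sulfur, not the amide, and it stays within the scatter.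

Compound 4 `CCN(CC)S(=O)(=O)c1ccc(S(=O)(=O)N2CCC[C@@H](C(=O)N3CCC(C(F)(F)F)CC3)C2)cc1` is not yet measured. It differs from compound 3 in one place: 4-(trifluoromethyl)piperidin-1-yl in place of morpholin-4-yl on a carbonyl carbon. Within the data shown here, no measured step matches this change directly. Compound 1 and compound 2 carry a fluorinated piperidine on the carbonyl carbon where compound 3 carries morpholine, and both give much lower numbers than compound 3, yet they also differ from compound 3 on the sulfonyl sulfur, so their values only hint at the direction. On this basis compound 4 is expected to give a lower number than compound 3, the expected step being a 4.6-fold lower number from compound 3 to compound 4 (0.66 log units; beyond the scatter). The estimate for compound 4 in this assay is 35 nM, with a range from 10 nM to 120 nM.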

Compound 4, half-maximal inhibitory concentration: 110 nM
The estimate for compound 4 lay 3.1-fold (0.50 log units) below the measured number, within the range that was stated.
By their numbers in this assay, from the lowest: compounds 2 and 1 (each within the scatter of the next); then compounds 4 and 3 (each within the scatter of the next).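

In this assay the ring on the carbonyl carbon now changes on its own, with the rest of the molecule held fixed, and the swap gives a 1.5-fold lower number from compound 3 to compound 4 (0.16 log units; within the scatter). Morpholin-4-yl, with 6 heavy atoms and 1 hydrogen-bond acceptor, gives way to 4-(trifluoromethyl)piperidin-1-yl, with 10 heavy atoms and 0 hydrogen-bond acceptors, yet the numbers of the two compounds cannot be told apart, so this position accepts this particular change without a readable effect on the read-out. Nothing available explains why the two rings read alike.

Still open, on these data alone, is whether any other group on this carbonyl carbon would move the number beyond the scatter with the rest of the molecule held fixed, for example a plain piperidine or a piperidine carrying a carboxylic acid or a primary amine. Going by these compounds alone, also open is what further changes on the sulfonyl sulfur would do with the amide ring held fixed, such as a longer chain like n-butyl, given that the only step there so far is a 1.4-fold lower number from compound 1 to compound 2 (0.14 log units; within the scatter), which lies within the scatter.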